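An Amino Group in Place of Fluorine on Compound 1

The compounds below may be only part of what the source reports. "The series", "measured", "known", "first", "only" and "open" are said of these compounds alone.

Compound 1 `Fc1cccc(-c2nc(Nc3ccccc3F)c3cc(F)ccc3n2)c1` is the reference point of this account. On these data alone, in a functional assay on U2OS cells (Homo sapiens) for cytotoxicity, read by MTT assay, with a stated time of 48 h (on this read-out higher numbers stand for weaker inhibition and lower numbers for stronger inhibition), compound 1 gives only a limit of the assay, > 50000 nM, so where it stands on the scale remains open. Two measured neighbours share its core. Compound 2 `Oc1ccccc1Nc1nc(-c2cccc(F)c2)nc2ccc(F)cc12`, with hydroxy in place of fluoro on an aromatic carbon, gives 41400 nM in this assay. Compound 3 `Nc1cccc(Nc2nc(-c3cccc(F)c3)nc3ccc(F)cc23)c1`, with 3-aminophenyl in place of 2-fluorophenyl on a nitrogen on an aromatic ring, gives 49700 nM in this assay. The steps of an at least 1.2-fold lower number from compound 1 to compound 2 (0.08 log units; that floor lies within the scatter) and a 1.2-fold higher number from compound 2 to compound 3 (0.08 log units; within the scatter) stay within the scatter, and the step of a number no higher from compound 1 to compound 3 (the limit leaves the size open) cannot be sized because the limit of > 50000 nM in this assay, at which 1 of the 3 values shown sits, sits at its start.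

Compound 4 `Nc1ccccc1Nc1nc(-c2cccc(F)c2)nc2ccc(F)cc12` differs from compound 1 by amino in place of fluoro on an aromatic carbon. The nearest measured step, hydroxy for fluoro at the same place, and the amino group entering in compound 3 both left the number close to the values of compound 2 and compound 3. Compound 4 is therefore expected in this assay at 45000 nM, within 20000 nM to 100000 nM. The step of an at least 1.1-fold lower number from compound 1 to compound 4 (0.04 log units; that floor lies within the scatter) is expected to stay within the scatter, with a fair chance that only a limit is reported again.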

Compound 4, half-maximal inhibitory concentration: 37900 nM
Beside the measured number, compound 4's estimate is 1.2-fold (0.07 log units) above it; measured number inside the range.
By their numbers in this assay, from the lowest: compounds 4, 2 and 3 (each within the scatter of the next). At a limit, above all of these: compound 1.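

On the 2-aminophenyl ring, amino in place of hydroxy gives a 1.1-fold lower number from compound 2 to compound 4 (0.04 log units; within the scatter), and 2-aminophenyl in place of 3-aminophenyl gives a 1.3-fold lower number from compound 3 to compound 4 (0.12 log units; within the scatter), so in this assay neither the choice between these two groups at this carbon nor the amino group's place on the ring separates these compounds. Amino in place of fluoro gives an at least 1.3-fold lower number from compound 1 to compound 4 (0.12 log units; that floor lies within the scatter), which adds a second group to hydroxy that brings a measured number at this carbon. The true size of that step stays unread because compound 1 stands at a limit rather than a number: the limit of > 50000 nM in this assay, at which 1 of the 4 values shown sits.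

On these data alone, whether a methoxy group, a dimethylamino group or a carboxylic acid at this carbon would move the number beyond the scatter stays open. So does whether any group here would bring a much lower number.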